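Trifluoromethyl in Place of Hydroxy: An Expected Step

The source may report more compounds than this note shows. Statements on the series, on what has been measured and on what is new or still open speak of the compounds shown alone.

Compound 1, `O=C(Nc1cccc(O)c1)c1nccc2ccccc12`, is an amide in which the aromatic ring on the nitrogen side carries a hydroxy group. In a functional assay on NUGC-3 cells (Homo sapiens) for inhibition, read by sulforhodamine B assay, with a stated time of 48 h (on this read-out lower numbers stand for stronger inhibition of growth and higher numbers for weaker inhibition of growth), compound 1 gives > 10000 nM, which is a limit of the assay rather than a measured number. Two further compounds share the amide motif. Compound 2, `O=C(Nc1cc(C(F)(F)F)cc(C(F)(F)F)c1)C1NCCc2ccccc21`, carries two trifluoromethyl groups on that ring and a saturated core; in this assay compound 2 gives > 10000 nM, again a limit. Compound 3, `O=C(Nc1ccc(C(F)(F)F)cc1)C1c2ccccc2CCN1C(=O)c1ccc(Cl)cc1`, carries one trifluoromethyl group and a second amide on its core; in this assay compound 3 gives 4200 nM, a measured number. Taken together, the limit of > 10000 nM in this assay, at which 2 of the 3 values shown sit, describes where compound 1 stands: at the edge of what the assay can report.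

Compound 4, `O=C(Nc1cccc(C(F)(F)F)c1)c1nccc2ccccc12`, differs from compound 1 in a single place: trifluoromethyl in place of hydroxy on an aromatic carbon. Within the data shown here, no pair of measured compounds isolates this change, so no measured step is available. The expected step from compound 1 to compound 4 is an at least 1.4-fold lower number from compound 1 to compound 4 (0.15 log units; that floor lies within the scatter), a modest move toward stronger inhibition. That expectation rests on compound 3, which carries one trifluoromethyl and gives 4200 nM. Compound 4 is estimated at 7000 nM, with a range from 2000 nM to 25000 nM, and a real chance remains that it also returns only a limit.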

Compound 4, concentration for 50% growth inhibition: > 10000 nM
Compound 4 ended at the assay's limit (the forecaster's own chance of this, stated with the estimate: 45%); middle value at least 1.4-fold (0.15 log units) away from the limit.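

Among these compounds, compound 4, like compound 1, returns only a limit in this assay, so no step between the two can be read. Most of the series now sits at that edge: the limit of > 10000 nM in this assay, at which 3 of the 4 values shown sit. Going by these compounds, whether trifluoromethyl in place of hydroxy on an aromatic carbon strengthens, weakens or leaves unchanged the inhibition of growth stays open.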